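Benzothiophenyl in place of ethyl on the shared core

A few compounds are considered here, and "the series" means these few. Any claim that something is new, unique, unknown or untested is made for them only; others in the source may bear on it.

Measured compounds:
compound 1, `CCOC(=O)c1cnc(N(C(=O)NC)N2C(=O)C=C(C)C2=O)nc1C(F)(F)F`: 590 nM
compound 2, `CCOC(=O)c1cnc(NN2C(=O)C=C(C)C2=O)nc1CC`: 400 nM

Of the compounds shown here, two have been tested in a functional assay on Jurkat cells (Homo sapiens) for inhibition; on this read-out higher numbers stand for weaker inhibition and lower numbers for stronger inhibition. Compound 1 gives 590 nM in this assay, and compound 2 gives 400 nM. These two numbers lie within the scatter of each other, so the data do not separate the two compounds; compound 2 simply holds the lower of the two numbers, with compound 1 nearest to it.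

The next compound is compound 3, `CCOC(=O)c1cnc(NN2C(=O)C=C(C)C2=O)nc1-c1cc2ccccc2s1`, which has not yet been measured in this assay. It differs from compound 2 in one place: 1-benzothiophen-2-yl in place of ethyl on an aromatic carbon. For the measured compounds named here, no step between two measured compounds covers a change of this kind, so nothing in the data points in either direction. The step of a 1.3-fold higher number from compound 2 to compound 3 (0.10 log units; within the scatter) is therefore expected to be small, not clearly beyond the scatter. For compound 3 the estimate in this assay is 500 nM, with a range from 100 nM to 3000 nM.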

Compound 3, half-maximal inhibitory concentration: 800 nM
Estimate against measurement, compound 3: 1.6-fold (0.20 log units) below, within the range that was stated.
By their numbers in this assay, from the lowest: compounds 2, 1 and 3 (each within the scatter of the next).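

In this assay, for the compounds shown here, the step of a 2.0-fold higher number from compound 2 to compound 3 (0.30 log units; within the scatter) is the first that can be read at this position, on an aromatic carbon ortho to an ethoxycarbonyl group. 1-Benzothiophen-2-yl brings 9 heavy atoms and two aromatic rings where ethyl has 2 heavy atoms and no ring, yet this read-out does not separate the two compounds, so a much larger group at this position need not move the number beyond the scatter. The data offer no measurement that would explain this result.

The compounds shown leave open whether an amine, a carboxylic acid or a longer alkyl chain at this position would give a number beyond the scatter of compound 2. They also leave open whether 1-benzothiophen-2-yl would read the same on the core of compound 1.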